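Formyl for Ethyl on a Pendant Phenyl Ring

This account rests on a few compounds, and the source may have more. Where it says the series, first, only, none or still open, it means among the compounds named here.

The measured compounds and their values in a functional assay on SF-539 cells (Homo sapiens) for inhibition, read by sulforhodamine B assay, with a stated time of 48 h, tested at 10 uM; on this read-out higher numbers stand for more inhibition at the one concentration tested (going by the name of the read-out) and lower numbers for less inhibition:
compound 1, `Fc1ccc(-c2cn3ccnc3c(-c3ccc4ncn(C5CCCCC5)c4c3)n2)cc1`, 17.3%
compound 2, `Fc1ccccc1-c1cn2ccnc2c(-c2ccc3ncn(C4CCCCC4)c3c2)n1`, 4.51%
compound 3, `CCc1ccc(-c2cn3ccnc3c(-c3ccc4ncn(Cc5ccccc5)c4c3)n2)cc1`, 21.2%

Compound 3 gives the highest of the three numbers in this assay. Its value sits within the scatter of compound 1, so no order between compound 3 and compound 1 can be drawn, while compound 2 lies beyond the scatter below it. Going by the values given here, the only step between measured compounds, a number 12.8 percentage points lower from compound 1 to compound 2 (beyond the scatter), concerns the position of a fluorine on the phenyl ring and not the group that changes here.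

Compound 4, `O=Cc1ccc(-c2cn3ccnc3c(-c3ccc4ncn(Cc5ccccc5)c4c3)n2)cc1`, differs from compound 3 by formyl in place of ethyl on an aromatic carbon. Among the compounds with values here, no measured step bears on this exchange: none of the three compounds carries a formyl group, and the one measured step involves a different part of the molecule. The expectation for compound 4 is therefore no step beyond the scatter, with a number 1.2 percentage points lower from compound 3 to compound 4 (within the scatter) reflecting the value of compound 3 carried over with wide uncertainty. Compound 4 is estimated at 20%, within a range from 5% to 38%.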

Compound 4, a percentage reported as inhibition, at one concentration (the size of the read-out at that concentration, not a potency): 31.5%
Compound 4: the middle estimate sits 11.5 percentage points below what was measured; the measured number falls inside the stated range.
By their numbers in this assay, from the lowest: compound 2; then compounds 1 and 3 (each within the scatter of the next); then compound 4.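

Going by these compounds alone, replacing the ethyl of compound 3 with a formyl group gives the first measured step at this position, para to a large group on the pendant phenyl ring: in this assay, the change is a number 10.3 percentage points higher from compound 3 to compound 4 (beyond the scatter). The earlier compounds shown here showed only that moving a fluorine on a phenyl ring changed the number, whereas this step shows that exchanging one group of 2 heavy atoms for another at this position also does so. No measurement at hand explains this difference between 4-ethylphenyl and 4-formylphenyl.

The compounds shown leave open how an amine, a carboxylic acid or a longer chain would read at this position. They also leave open whether the same exchange would give a similar step on the core of compound 1.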